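The source may hold more compounds than are shown below. What is called first, only, known or untested is meant among the compounds shown, and "the series" means these compounds.

Measured in an assay on cells with melanin-concentrating hormone receptor 1 (Homo sapiens) as the target, read by radioligand binding; a lower number here means a stronger inhibitor, a higher number a weaker inhibitor:
compound 1 `CCCCCOc1cccc2ccc(N)nc12` gives 580 nM
compound 2 `CC(C)=CCOc1cccc2ccc(N)nc12` gives > 2000 nM

Compound 2 sits at the weaker end of this pair. The value recorded for compound 2 is a limit of this assay, not a number, as noted by the limit of > 2000 nM in this assay, at which 1 of the 2 values shown sits. Compound 3 `CCCC(C)Oc1cccc2ccc(N)nc12` differs from compound 2 by 1-methylbutyl in place of 3-methylbut-2-en-1-yl on an oxygen on an aromatic ring. Within the data shown here, the only measured step that bears on this change is an at least 3.4-fold higher number from compound 1 to compound 2 (0.53 log units; beyond the scatter), in which a saturated chain gave way to an unsaturated one. The move from compound 2 to compound 3 runs the other way: the double bond leaves and a saturated chain of the same count returns, though now as the branched 1-methylbutyl rather than a straight chain. What the branching on its own does is not shown by the two compounds measured. The expected step is an at least 2.5-fold lower number from compound 2 to compound 3 (0.39 log units; beyond the scatter), a recovery toward the level of compound 1 rather than beyond it. The estimate for compound 3 in this assay is 800 nM, within 300 nM to 3000 nM.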

Compound 3, half-maximal inhibitory concentration: 105 nM
For compound 3 the middle estimate is 7.6-fold (0.88 log units) above the measured one, and the stated range ends above it.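

On an oxygen on an aromatic ring, the branched 1-methylbutyl gives a stronger result in this assay than the straight pentyl, with a 5.5-fold lower number from compound 1 to compound 3 (0.74 log units; beyond the scatter), so the shape of a saturated chain matters here and not only the absence of a double bond. Against 3-methylbut-2-en-1-yl the gap is wider, with an at least 19-fold lower number from compound 2 to compound 3 (1.27 log units; beyond the scatter). The value of compound 2 is a limit and not a number, so that step gives only a minimum size: the limit of > 2000 nM in this assay, at which 1 of the 3 values shown sits.

From the compounds shown here alone, whether a shorter branched chain such as isopropyl, a longer one such as 1-methylpentyl, or a ring such as cyclopentyl on this oxygen keeps or improves on the level of compound 3 remains open. Also open, going by these compounds, is whether the two mirror-image forms of 1-methylbutyl differ in this assay.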